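The source may report more compounds than this note shows. Statements on the series, on what has been measured and on what is new or still open speak of the compounds shown alone.

Measured in a functional assay on the whole organism (strain Wistar) for inhibition, with Rattus norvegicus as the target, read by paw edema, with stated times of 30 min and 3 h, at a dose of 100 mg/kg by the oral route; a higher number here means a stronger effect of the compound at the dose given, a lower number a weaker effect:
compound 1 `CCOc1c(NC)cnn(C)c1=O`, 31.1%
compound 2 `CCCNc1cnn(C)c(=O)c1OCC`, 38%

Compound 2 stands highest of the two numbers in this assay, with 38%; the nearest is compound 1, which gives 31.1%. Within the data shown here, the only measured step, a number 6.9 percentage points higher from compound 1 to compound 2 (within the scatter), lies within the scatter, so no order between the two can be stated on these numbers.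

Compound 3 `CCOc1c(N(C)C)cnn(C)c1=O` is the next compound to be measured. It differs from compound 2 by dimethylamino in place of propylamino on an aromatic carbon. The change removes the one hydrogen-bond donor of the propylamino group and brings two carbons on the nitrogen where compound 2 carries a three-carbon chain with a hydrogen.

Among the measured compounds shown here, no measured step bears directly on this change. The step of a number 6.9 percentage points higher from compound 1 to compound 2 (within the scatter) shows that lengthening the chain on that nitrogen from hydrogen to ethyl did not move the number beyond the scatter, but it says nothing about removing the donor, and a single step within the scatter gives no direction. The expectation for compound 3 is therefore a step of a number 5 percentage points lower from compound 2 to compound 3 (within the scatter), not beyond the scatter, with wide uncertainty. Compound 3 is estimated at 33%, within 15% to 52%.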

Compound 3, a percentage reported as inhibition, in the whole organism at one dose (the size of the read-out at that dose, not a potency): 49.5%
Estimate against measurement, compound 3: 16.5 percentage points below; measured number inside the range.
By their numbers in this assay, from the lowest: compounds 1 and 2 (each within the scatter of the next); then compound 3.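

In this assay, the group on this aromatic carbon now gives steps beyond the scatter: dimethylamino in place of propylamino gives a number 11.5 percentage points higher from compound 2 to compound 3 (beyond the scatter), and methyl in place of hydrogen on the nitrogen gives a number 18.4 percentage points higher from compound 1 to compound 3 (beyond the scatter). Among the three compounds shown, the one with no hydrogen-bond donor in this group stands above the other two, which lie within the scatter of each other, so the length of the chain on the nitrogen has not separated compounds so far, while the dimethylamino group has. No measurement shown explains this rise, and with dimethylamino as the only group of its kind, the loss of the donor cannot be separated from the other differences between the groups.

Going by these compounds, whether the rise extends to other groups on this nitrogen remains open, for example diethylamino, a longer chain on a fully substituted nitrogen, or a cyclic amine such as morpholine. All three numbers are also read at one dose, so they give the size of the effect at that dose and leave the response at other doses open.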